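A few compounds are considered here, and "the series" means these few. Any claim that something is new, unique, unknown or untested is made for them only; others in the source may bear on it.

Working notes on the series.

Compound 2 `Cc1cc(C(=O)N2CCCCc3ccccc32)ccc1CNC(=O)NCC(=O)N(C)C` carries the higher of the two numbers recorded so far in a functional assay on HEK293 cells for agonist activity at Vasopressin V2 receptor (Rattus norvegicus), read by a luciferase reporter and cAMP accumulation; a higher number here means that more compound is needed for the effect, a lower number that less compound is needed: compound 2 gives 50 nM, while compound 1 `Cc1cc(C(=O)N2CCCCc3ccccc32)ccc1CNC(=O)Nc1c(F)cccc1F` gives 13 nM in this assay. Among the measured compounds shown here, the one measured step runs a 3.8-fold higher number from compound 1 to compound 2 (0.59 log units; beyond the scatter), a modest rise on exchanging the group on the amide-type nitrogen.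

Compound 3 `Cc1cc(C(=O)N2CCCCc3ccccc32)ccc1CNC(=O)N1C[C@H](O)C[C@H]1C(=O)N(C)C` differs from compound 2 by 2-(dimethylcarbamoyl)-4-hydroxypyrrolidin-1-yl in place of ((dimethylcarbamoyl)methyl)amino on a carbonyl carbon, a swap that closes the open chain into a five-membered ring bearing a hydroxyl and the dimethylcarbamoyl. For the measured compounds named here, no measured step covers this kind of change; the step from compound 1 to compound 2 concerns a different exchange at the same terminus and only shows that this end tolerates rearrangement at modest cost. Going by the values given here, with no direct precedent, the expected step in this assay is a 1.3-fold lower number from compound 2 to compound 3 (0.10 log units; within the scatter), that is, nothing clearly beyond the scatter. For compound 3 the estimate in this assay is 40 nM, with a range from 10 nM to 160 nM.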

Compound 3, half-maximal effective concentration: 41 nM
The estimate for compound 3 lay 1.0-fold (0.01 log units) below the measured number, and the stated range covers the measured number.
By their numbers in this assay, from the lowest: compound 1; then compounds 3 and 2 (each within the scatter of the next).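

In this assay, closing the open chain into 2-(dimethylcarbamoyl)-4-hydroxypyrrolidin-1-yl on the carbonyl carbon gives a 1.2-fold lower number from compound 2 to compound 3 (0.09 log units; within the scatter) and so shows that this position accepts the five-membered ring, its hydroxyl and both defined stereocentres with no readable shift. Set against the (2,6-difluorophenyl)amino group, the same ring gives a 3.2-fold higher number from compound 1 to compound 3 (0.50 log units; beyond the scatter) and thus places both dimethylcarbamoyl-bearing groups on the same side of compound 1, which keeps the lowest number of the three. No measured finding accounts for either step.

The compounds shown do not separate the ring from the hydroxyl or from the two stereocentres, since compound 3 brings them in together. Also open, going by these compounds, is how this position would read with a plain pyrrolidine, or with a carboxylic acid in place of the dimethylcarbamoyl.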